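The compounds below may be only part of what the source reports. "The series", "measured", "known", "first", "only" and "open" are said of these compounds alone.

Of the compounds shown here, three have been measured in a functional assay on CHO-K1 cells for antagonist activity at cysteinyl leukotriene receptor 1 (Homo sapiens), read by fluorescence and calcium flux, with stated times of 30 min and 1 h; on this read-out higher numbers stand for weaker inhibition and lower numbers for stronger inhibition. Compound 1 `Cc1c(F)cccc1CCCCOc1ccc(C#Cc2cccc3c(CCCC(=O)O)c(C)n(CCCC(=O)O)c23)cc1` gives 1.1 nM, compound 2 `Cc1c(Cl)cccc1CCCCOc1ccc(C#Cc2ccc(F)c3c(CCCC(=O)O)c(C)n(CCCC(=O)O)c23)cc1` gives 3.4 nM, and compound 3 `Cc1c(CCCC(=O)O)c2cccc(/C=C/c3ccc(OCCCCc4ccccc4)cc3)c2n1CC(=O)O` gives 4.1 nM. Compound 3 carries the highest number of the three, yet the value of compound 2 lies within the scatter of it, while compound 1 sits beyond the scatter below it. Compound 4 `Cc1c(CCCC(=O)O)c2cccc(/C=C/c3ccc(OCCCCc4c(F)c(F)cc(F)c4F)cc3)c2n1CC(=O)O` differs from compound 3 in one place: 2,3,5,6-tetrafluorophenyl in place of phenyl on a saturated chain carbon, four bonds along the chain from an oxygen on an aromatic ring. Going by the values given here, no measured pair isolates this change, so the numbers at hand give no direction for it. Compound 4 is therefore expected to move by a step of a 1.1-fold higher number from compound 3 to compound 4 (0.04 log units; within the scatter), not beyond the scatter. The estimated value of compound 4 in this assay is 4.5 nM, with a range from 1.5 nM to 14 nM.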

Compound 4, half-maximal inhibitory concentration: 2.2 nM
Compound 4: the middle estimate sits 2.0-fold (0.31 log units) above what was measured; the range from low to high includes it.
By their numbers in this assay, from the lowest: compounds 1, 4, 2 and 3 (each within the scatter of the next, the first and the last beyond it).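

In this assay, 2,3,5,6-tetrafluorophenyl in place of phenyl on a saturated chain carbon, four bonds along the chain from an oxygen on an aromatic ring, gives a 1.9-fold lower number from compound 3 to compound 4 (0.27 log units; within the scatter). Going by these compounds alone, this pair is the first to isolate a change at this position, and it shows that replacing four ring hydrogens with fluorine leaves the number within the scatter. No measurement at hand offers an explanation for this step. As far as these compounds go, whether a pyridyl or cyclohexyl group at this position would move the number beyond the scatter remains open.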